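The source may hold more compounds than are shown below. What is called first, only, known or untested is meant among the compounds shown, and "the series" means these compounds.

Two compounds built on the same core differ only in the group on the aromatic nitrogen. In a functional assay on HepG2 cells (Homo sapiens) for cytotoxicity, read by MTT assay, with a stated time of 72 h (a higher number here means a weaker inhibitor, a lower number a stronger inhibitor), compound 1 `Cc1cc(=O)n(-c2ccccc2C(F)(F)F)nc1C(=O)Nc1ccc(Oc2ncnc3ccsc23)c(F)c1` gives 9380 nM. In this assay compound 2 `Cc1cc(=O)n(-c2cccc(F)c2)nc1C(=O)Nc1ccc(Oc2ncnc3ccsc23)c(F)c1` gives 7810 nM, the lowest of the two numbers, with compound 1 nearest: the step of a 1.2-fold lower number from compound 1 to compound 2 (0.08 log units; within the scatter). Compound 3 `Cc1cc(=O)n(-c2ccc(F)c(F)c2)nc1C(=O)Nc1ccc(Oc2ncnc3ccsc23)c(F)c1` carries fluoro in place of hydrogen on an aromatic carbon. That single measured step changed the whole group on the aromatic nitrogen yet stayed within the scatter, so the smaller change here is expected to give a 1.1-fold lower number from compound 2 to compound 3 (0.05 log units; within the scatter). Compound 3 is therefore estimated at 7000 nM, ranging from 3000 nM to 16000 nM.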

Compound 3, half-maximal inhibitory concentration: 6930 nM
Compound 3: middle estimate off by 1.0-fold (0.00 log units), on the high side; the measured number falls inside the stated range.
By their numbers in this assay, from the lowest: compounds 3, 2 and 1 (each within the scatter of the next).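

In this assay, adding fluoro to the aromatic carbon ortho to a fluoro group and para to a large group, which turns 3-fluorophenyl into 3,4-difluorophenyl, gives a 1.1-fold lower number from compound 2 to compound 3 (0.05 log units; within the scatter) and so leaves the number within the scatter. The larger swap of 2-(trifluoromethyl)phenyl for 3,4-difluorophenyl on the aromatic nitrogen gives a 1.4-fold lower number from compound 1 to compound 3 (0.13 log units; within the scatter) and so does not separate these two compounds either. No measurement is available that explains these results.

The compounds shown leave open whether an amine or a carboxylic acid on this phenyl ring would shift the number beyond the scatter.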